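Methyl for chloro on the shared core: permeability outlook

The source may hold more compounds than are shown below. What is called first, only, known or untested is meant among the compounds shown, and "the series" means these compounds.

Compound 1 `COc1ccc2c(O[C@@H]3C[C@H]4C(=O)N[C@]5(C(=O)NS(=O)(=O)C6CC6)C[C@H]5/C=C\CCCCCNC(=O)N4C3)cc(-c3nc(C(C)C)cs3)nc2c1` and compound 2 `COc1ccc2c(O[C@@H]3C[C@H]4C(=O)N[C@]5(C(=O)NS(=O)(=O)C6CC6)C[C@H]5/C=C\CCCCCNC(=O)N4C3)cc(-c3nc(C(C)C)cs3)nc2c1Cl` share one core. In an ADME assay on Caco-2 cells (Homo sapiens) for permeability, in the apical to basolateral direction (a higher number here means that the compound crosses the layer faster, a lower number that the compound crosses the layer more slowly), compound 1 gives 10 10^-6 cm/s, and compound 2 gives 22 10^-6 cm/s, the higher of the two numbers. Going by the values given here, the single measured step, a 2.2-fold higher number from compound 1 to compound 2 (0.34 log units; beyond the scatter), is a chloro in place of hydrogen on an aromatic carbon. Compound 3 `COc1ccc2c(O[C@@H]3C[C@H]4C(=O)N[C@]5(C(=O)NS(=O)(=O)C6CC6)C[C@H]5/C=C\CCCCCNC(=O)N4C3)cc(-c3nc(C(C)C)cs3)nc2c1C` changes that same site: methyl in place of chloro on an aromatic carbon, on an aromatic carbon of a six-membered aromatic ring of carbon only, ortho to a methoxy group. Among the compounds with values here, only the step between compound 1 and compound 2 bears on this, and it was modest, so for compound 3 a step of no more than that size, and likely none beyond the scatter, is expected, a 1.2-fold lower number from compound 2 to compound 3 (0.09 log units; within the scatter). Compound 3 is estimated at 18 10^-6 cm/s, within 9 10^-6 cm/s to 32 10^-6 cm/s.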

Compound 3, apparent permeability: 0.4 10^-6 cm/s
For compound 3 the middle estimate is 45-fold (1.65 log units) above the measured one, and the stated range ends above it.
By their numbers in this assay, from the lowest: compound 3; then compound 1; then compound 2.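

At this position on the shared core, methyl in place of hydrogen gives a 25-fold lower number from compound 1 to compound 3 (1.40 log units; beyond the scatter) in this assay, and methyl in place of chloro gives a 55-fold lower number from compound 2 to compound 3 (1.74 log units; beyond the scatter), so the site is far more sensitive than the earlier step showed. Chloro and methyl each count one heavy atom and no hydrogen-bond donors or acceptors, yet they move the number in opposite directions from hydrogen. Nothing available here accounts for the drop. From the compounds shown here alone, whether the drop is particular to methyl stays open. Fluoro or ethyl on this carbon would show whether other groups follow chloro or methyl.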